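This account rests on a few compounds, and the source may have more. Where it says the series, first, only, none or still open, it means among the compounds named here.

Compounds measured so far in a functional assay on MV4-11 cells (Homo sapiens) for cytotoxicity, read by MTT assay, with a stated time of 72 h; on this read-out lower numbers stand for stronger inhibition and higher numbers for weaker inhibition:
compound 1 `CC(C)(C)c1cc(NC(=O)Nc2ccc(-c3cn4cccnc4n3)cc2)no1`: 171 nM
compound 2 `CC(C)(C)c1cc(NC(=O)Nc2ccc(-c3cn4ccncc4n3)cc2)no1`: 44.8 nM

Compound 2 gives the lowest number of the two, and the step of a 3.8-fold lower number from compound 1 to compound 2 (0.58 log units; beyond the scatter) lies beyond the scatter. Compound 3 `CC(C)(C)c1cc(NC(=O)Nc2ccc(-c3cc4ccccc4s3)cc2)no1` differs from compound 2 by a group of 9 heavy atoms (8 carbon, 1 sulfur; one five-membered aromatic ring with 1 hetero atom, one six-membered aromatic ring of carbon only) in place of a group of 9 heavy atoms (6 carbon, 3 nitrogen; one five-membered aromatic ring with 2 hetero atoms, one six-membered aromatic ring with 2 hetero atoms), on an aromatic carbon. For the measured compounds named here, no measured step covers this kind of exchange; the only step known, a 3.8-fold lower number from compound 1 to compound 2 (0.58 log units; beyond the scatter), swaps two closely related groups and is modest. The estimate for compound 3 in this assay is therefore uncertain, with the number expected to rise, an 8.9-fold higher number from compound 2 to compound 3 (0.95 log units; beyond the scatter). Compound 3 is expected at about 400 nM, between 100 nM and 2000 nM.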

Compound 3, half-maximal inhibitory concentration: > 900 nM
Compound 3 ended at the assay's limit; the forecaster's own chance of this, stated with the estimate: 10%; middle value at least 2.2-fold (0.35 log units) away from the limit.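

At the place para to a large group, 1-benzothiophen-2-yl gives a far greater change than the swap between the two nitrogen-bearing groups: an at least 20-fold higher number from compound 2 to compound 3 (1.30 log units; beyond the scatter), and an at least 5.2-fold higher number from compound 1 to compound 3 (0.72 log units; beyond the scatter). The groups have equal heavy-atom counts, so this position is sensitive to more than size in this assay. The value of compound 3 is a limit, not a number: the limit of > 900 nM in this assay, at which 1 of the 3 values shown sits.

The compounds shown leave open how far beyond that limit compound 3 lies. They also leave open whether a 1-benzofuran-2-yl or plain phenyl group would behave like 1-benzothiophen-2-yl here.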